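The compounds below may be only part of what the source reports. "The series", "measured", "known", "first", "only" and "open" are said of these compounds alone.

Measured so far in an ADME assay on the whole organism (plasma, Homo sapiens) for protein binding, read by LC-MS, with a stated time of 24 h; on this read-out lower numbers stand for a smaller free fraction and higher numbers for a larger free fraction:
compound 1 `CN(C(=O)OCc1c(-c2ccc(O[C@H]3CCC[C@H](C(=O)O)C3)cn2)nnn1C)C1CCCC1`: 0.025
compound 2 `Cc1noc(-c2ccc(O[C@H]3CCC[C@H](C(=O)O)C3)cc2)c1COC(=O)N(C)C1CCCC1`: 0.004
compound 3 `Cc1nc(-c2nnn(C)c2COC(=O)N(C)CC2CCCC2)ccc1O[C@H]1CCC[C@H](C(=O)O)C1`: 0.012

Compound 2 stands lowest of the three numbers. Compound 3 is nearest to it and compound 1 furthest, and both gaps lie beyond the scatter, so compound 2 shows the smallest unbound fraction of the set. Going by the values given here, no two measured compounds differ in only one place, so no single step has been followed within the measured set.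

Compound 4 `Cc1noc(-c2ccc(O[C@H]3CCC[C@H](C(=O)O)C3)cc2)c1COC(=O)N(C)CCC(C)C` has not been measured. Its difference from compound 2 is isopentyl in place of cyclopentyl on an amide-type nitrogen. The site is an amide-type nitrogen whose other neighbours are a carbonyl carbon and a saturated chain carbon; cut one bond further out, cyclopentyl(methyl)amino becomes isopentyl(methyl)amino. The leaving and entering groups match in everything counted for them apart from the ring.

Among the compounds with values here, with no measured step of this kind available, the step from compound 2 to compound 4 in this assay is expected to be no change at the digits printed from compound 2 to compound 4 (within the scatter), that is, no change beyond the scatter in either direction. The unbound fraction of compound 4 is accordingly estimated at 0.004, within a range of 0.002 to 0.008.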

Compound 4, unbound fraction: 0.003
The estimate for compound 4 lay 1.3-fold (0.12 log units) above the measured number; low and high end bracket the measured number.
By their numbers in this assay, from the lowest: compounds 4 and 2 (each within the scatter of the next); then compound 3; then compound 1.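

In this assay, going by these compounds alone, isopentyl in place of cyclopentyl on the amide-type nitrogen gives a 1.3-fold lower number from compound 2 to compound 4 (0.12 log units; within the scatter), the first step that changes one place only. On the core of compound 2, the ring of the cyclopentyl group can therefore give way to an open chain with the same heavy-atom count without moving the unbound fraction beyond the scatter. Nothing at hand speaks to why the read-out holds across this change.

Going by these compounds, whether a cyclohexyl group, a shorter chain such as ethyl, or a chain carrying an amine or an ether oxygen on this nitrogen would shift the unbound fraction remains open. On these data alone, it also remains open whether the same exchange behaves alike on the core of compound 1.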